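This account rests on a few compounds, and the source may have more. Where it says the series, first, only, none or still open, it means among the compounds named here.

Measured compounds in a functional assay on MCF7 cells (Homo sapiens) for cytotoxicity, read by sulforhodamine B assay, with a stated time of 48 h; on this read-out lower numbers stand for stronger inhibition and higher numbers for weaker inhibition:
compound 1 `CC1=C(/C=C/C(=O)/C=C/c2ccccc2)C(C)(C)CCC1` — 10600 nM
compound 2 `CC1=C(/C=C/C(=O)/C=C/c2ccc(Cl)cc2)C(C)(C)CCC1` — 10200 nM
compound 3 `CC1=C(/C=C/C(=O)/C=C/c2ccc(F)cc2)C(C)(C)CCC1` — 6200 nM

Compound 2 stands second highest of the three numbers in this assay. Its nearest neighbour is compound 1, and the step of a 1.0-fold lower number from compound 1 to compound 2 (0.02 log units; within the scatter) is within the scatter; the step to compound 3, a 1.6-fold lower number from compound 2 to compound 3 (0.22 log units; within the scatter), is also within the scatter. The three values are therefore not separable from one another, and no order among compounds 1, 2 and 3 can be claimed.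

Compound 4 `COc1ccc(/C=C/C(=O)/C=C/C2=C(C)CCCC2(C)C)cc1` is not yet measured. Against compound 2 the change is methoxy in place of chloro on an aromatic carbon: a methoxy enters on an aromatic carbon of the six-membered aromatic ring of carbon only, para to a large group, where the chloro leaves. Within the data shown here, no measured step introduces a methoxy. The steps that touch the same aromatic carbon — a 1.0-fold lower number from compound 1 to compound 2 (0.02 log units; within the scatter), a 1.7-fold lower number from compound 1 to compound 3 (0.23 log units; within the scatter) and a 1.6-fold lower number from compound 2 to compound 3 (0.22 log units; within the scatter) — are all within the scatter, so the substituent at this position has so far not moved the number beyond noise. On that basis no step beyond the scatter is expected for compound 4 in this assay, in either direction; the expected step is a 1.2-fold lower number from compound 2 to compound 4 (0.08 log units; within the scatter). Compound 4 is estimated at 8500 nM, with a range from 3000 nM to 25000 nM.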

Compound 4, half-maximal inhibitory concentration: 19600 nM
Beside the measured number, compound 4's estimate is 2.3-fold (0.36 log units) below it, and the stated range covers the measured number.
By their numbers in this assay, from the lowest: compounds 3, 2, 1 and 4 (each within the scatter of the next, the first and the last beyond it).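

In this assay, this aromatic carbon, para to a large group, now gives its first step beyond the scatter, a 3.2-fold higher number from compound 3 to compound 4 (0.50 log units; beyond the scatter), though only a modest one, with methoxy in place of fluoro. The same entering group gives a 1.9-fold higher number from compound 2 to compound 4 (0.28 log units; within the scatter) and a 1.8-fold higher number from compound 1 to compound 4 (0.27 log units; within the scatter), and both stay within the scatter, so methoxy separates here from fluoro alone and not from chloro or hydrogen, which means the position is no longer wholly silent but the effect of the change depends on which of these substituents it is compared with. Nothing available on these compounds accounts for that single separated pair.

The compounds shown leave open whether an ethoxy group, a longer ether chain, a hydroxyl group or an amine on the same aromatic carbon would sit with methoxy, with fluoro or apart from both, and so whether the separation belongs to methoxy specifically or extends to other groups joined through oxygen or nitrogen. They also leave open whether the gap between the methoxy and fluoro compounds holds in a second cell line or with a different exposure time.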